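A third aryl group in a weakly cytotoxic series

The source may report more compounds than this note shows. Statements on the series, on what has been measured and on what is new or still open speak of the compounds shown alone.

Compound 1 `Cn1ccc2c(Oc3ccc(NC(=O)c4cc5cccnc5n(-c5ccccc5)c4=O)cc3F)ncnc21` gives 63200 nM
Compound 2 `Cn1ccc2c(Oc3ccc(NC(=O)c4cc5cccnc5n(-c5ccc(Cl)cc5)c4=O)cc3F)ncnc21` gives 55500 nM

Going by the values given here, in a functional assay on A549 cells (Homo sapiens) for cytotoxicity, read by MTT assay, with a stated time of 72 h (a lower number here means a stronger inhibitor, a higher number a weaker inhibitor), compound 2 stands within the scatter of compound 1, the only other compound measured. Going on to compound 3 `Cn1ccc2c(Oc3ccc(NC(=O)c4cc5cccnc5n(-c5ccc(C(F)(F)F)c(Cl)c5)c4=O)cc3F)ncnc21` brings 3-chloro-4-(trifluoromethyl)phenyl in place of 4-chlorophenyl on an aromatic nitrogen on the same aromatic nitrogen. Among the compounds with values here, one measured step bears on this change, since it also adds chloro to that phenyl ring: a 1.1-fold lower number from compound 1 to compound 2 (0.06 log units; within the scatter) stays within the scatter. That single step offers no sign of a large shift, though it cannot show how trifluoromethyl will behave. The estimated change is a 1.2-fold lower number from compound 2 to compound 3 (0.09 log units; within the scatter) and no step beyond the scatter is expected. Compound 3 is expected at 45000 nM (estimated range 15000 nM to 100000 nM).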

Compound 3, half-maximal inhibitory concentration: 320000 nM
The estimate for compound 3 lay 7.1-fold (0.85 log units) below the measured number, outside the stated range (above it).
By their numbers in this assay, from the lowest: compounds 2 and 1 (each within the scatter of the next); then compound 3.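

In this assay, the aryl group on this aromatic nitrogen can shift the number beyond the scatter, which the change to 4-chlorophenyl had not done: the new group gives a 5.8-fold higher number from compound 2 to compound 3 (0.76 log units; beyond the scatter) and a 5.1-fold higher number from compound 1 to compound 3 (0.70 log units; beyond the scatter). So 3-chloro-4-(trifluoromethyl)phenyl is a weaker choice here than either phenyl or 4-chlorophenyl. Nothing measured here accounts for this shift. The compounds shown leave open whether trifluoromethyl alone on that phenyl ring would give the same shift, and how an amine or a carboxylic acid there would behave.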